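The source may report more compounds than this note shows. Statements on the series, on what has been measured and on what is new or still open speak of the compounds shown alone.

Working notes on the series. Compound 1 `CCc1ccc(S(=O)(=O)NC(=O)Nc2ccc(Cl)cc2)s1` gives 57% in a functional assay on the whole organism (6C3HED cells, Mus musculus) for inhibition, at a dose of 150 mg/kg by the oral route; on this read-out lower numbers stand for less inhibition and higher numbers for more inhibition at the one dose given (going by the name of the read-out). Compound 2 `CCOc1ccc(S(=O)(=O)NC(=O)Nc2ccc(Cl)cc2)s1` gives 69%, and compound 3 `CCCOc1ccc(S(=O)(=O)NC(=O)Nc2ccc(Cl)cc2)s1` gives 44%. Compound 1 stands second highest of the three numbers, with compound 2 nearest at a number 12 percentage points higher from compound 1 to compound 2 (beyond the scatter) and compound 3 furthest at a number 13 percentage points lower from compound 1 to compound 3 (beyond the scatter).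

Compound 4 `COc1csc(S(=O)(=O)NC(=O)Nc2ccc(Cl)cc2)c1` is not yet measured. The change from compound 1 is 4-methoxythiophen-2-yl in place of 5-ethylthiophen-2-yl on a sulfonyl sulfur. Two measured steps bear on it: ethoxy in place of ethyl gave a number 12 percentage points higher from compound 1 to compound 2 (beyond the scatter), and propoxy against ethoxy gave a number 25 percentage points lower from compound 2 to compound 3 (beyond the scatter), so among these three the shorter alkoxy went with the higher number. Going by the values given here, the entering 4-methoxythiophen-2-yl, however, differs from 5-ethylthiophen-2-yl in more than the alkyl-to-alkoxy swap, and no measured step covers that part, nor methoxy against ethoxy directly. The expectation for compound 4 is therefore a step of a number 1 percentage points higher from compound 1 to compound 4 (within the scatter), not confidently beyond the scatter in either direction. Compound 4 is estimated at 58%, with a range from 35% to 78%.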

Compound 4, a percentage reported as inhibition, in the whole organism at one dose (the size of the read-out at that dose, not a potency): 36%
For compound 4 the middle estimate is 22 percentage points above the measured one; the measured number falls inside the stated range.
By their numbers in this assay, from the lowest: compounds 4 and 3 (each within the scatter of the next); then compound 1; then compound 2.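

In this assay, 4-methoxythiophen-2-yl in place of 5-ethylthiophen-2-yl on the sulfonyl sulfur gives a number 21 percentage points lower from compound 1 to compound 4 (beyond the scatter), so a change that keeps the count of 7 heavy atoms and the five-membered aromatic ring still moves the number beyond the scatter. Where the step to compound 2 showed an oxygen-linked chain going with a higher number than ethyl, this step shows that an entering alkoxy group does not always do so at this position. No measured property bears on this step, and no cause can be given for it.

Still open, from the compounds shown here alone, is whether the fall follows the shorter methoxy chain or its different place on the ring. A 5-methoxythiophen-2-yl group on the sulfonyl sulfur would separate the two, and a 4-ethylthiophen-2-yl group would test the ring place without the oxygen.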